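Cytotoxicity limits across a shared oxazolidinone-bearing series

A few compounds are considered here, and "the series" means these few. Any claim that something is new, unique, unknown or untested is made for them only; others in the source may bear on it.

Measured compounds:
Compound 1 `O=C1CNC(=O)N1C[C@H]1CN(c2ccc(-n3cc(-c4ccccn4)cn3)c(F)c2)C(=O)O1` in an ADME assay on L02 cells (Homo sapiens) for cytotoxicity, read by MTT assay, with a stated time of 48 h (on this read-out higher numbers stand for weaker inhibition and lower numbers for stronger inhibition), gives > 400 ug/mL.
Compound 2 `COC[C@H]1CN(c2ccc(-n3cc(-c4ccccn4)cn3)c(F)c2)C(=O)O1` in this assay gives > 400 ug/mL.
Compound 3 `O=C(NC[C@H]1CN(c2ccc(-n3cc(-c4ccccn4)cn3)c(F)c2)C(=O)O1)C(F)F` in this assay gives > 400 ug/mL.

Each of these three values is a limit of this assay and not a number. Compound 3 therefore stands only at a limit, as do the two other measured compounds, with no reading inside the range. The steps a step that the two limits leave unreadable from compound 1 to compound 2, a step that the two limits leave unreadable from compound 1 to compound 3 and a step that the two limits leave unreadable from compound 2 to compound 3 are accordingly unreadable in size, because of the limit of > 400 ug/mL in this assay, at which 3 of the 3 values shown sit.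

Compound 4 `CNC(=O)[C@H]1CN(c2ccc(-n3cc(-c4ccccn4)cn3)c(F)c2)C(=O)O1` differs from compound 3 by methylcarbamoyl in place of (((difluoromethyl)carbonyl)amino)methyl on a saturated ring carbon. Among the measured compounds shown here, no measured step in this assay concerns this part of the molecule, and the steps that change the substituent on the saturated chain carbon gave no readable size. The three measured compounds agree only in sitting at the limit, so nothing points to a step beyond the scatter, in either direction, for the move to compound 4. The expected step of a number no higher from compound 3 to compound 4 (the limit leaves the size open) is therefore placed at none beyond the scatter. For compound 4 in this assay the estimate is 400 ug/mL, with a range from 200 ug/mL to 800 ug/mL, and a value reported only as a limit is expected.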

Compound 4, half-maximal inhibitory concentration: 217 ug/mL
Compound 4: the middle estimate sits 1.8-fold (0.27 log units) above what was measured; the measured number falls inside the stated range.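

In this assay, among the compounds shown here, compound 4 gives 217 ug/mL, the first reading that is a number and not a limit, and it comes from the first change placed directly on the saturated ring carbon next to the ring oxygen instead of on the saturated chain carbon. Against the three earlier compounds, this change reads as an at least 1.8-fold lower number from compound 3 to compound 4 (0.26 log units; that floor lies within the scatter), as an at least 1.8-fold lower number from compound 2 to compound 4 (0.26 log units; that floor lies within the scatter) and as an at least 1.8-fold lower number from compound 1 to compound 4 (0.26 log units; that floor lies within the scatter), so methylcarbamoyl at this position is not shown to differ from any of the three groups it replaces by more than the scatter, though the true size of each step may be larger. The steps among compound 1, compound 2 and compound 3 still cannot be read, and the new steps have only floors because their starting values are limits: the limit of > 400 ug/mL in this assay, at which 3 of the 4 values shown sit.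

The compounds shown leave open whether the number for compound 4 goes with the methylcarbamoyl group itself or with the loss of the chain carbon between the ring and the amide. A methylcarbamoylmethyl group at the same ring carbon would separate these two readings, and a carboxylic acid there would test how far the amide nitrogen and its methyl matter.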